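The compounds below may be only part of what the source reports. "The series", "measured", "known", "first", "only" and "open" are said of these compounds alone.

In a functional assay on MCF7 cells (Homo sapiens) for inhibition, read by CCK-8 assay, with a stated time of 48 h (a lower number here means a stronger inhibitor of growth, a higher number a weaker inhibitor of growth), compound 3 `COc1cccc(CNc2nc(Nc3ccc(N4CCN(C)CC4)cn3)ncc2Cl)c1` gives 19500 nM, and compound 2 `CN1CCN(c2ccc(Nc3ncc(Cl)c(NCc4ccccc4)n3)nc2)CC1` gives 17300 nM. Among the compounds with values here, these are the only two numbers so far, and they lie within the scatter of each other. Compound 1 `Cc1ccccc1Nc1nc(Nc2ccccc2)ncc1Cl` reads > 100000 nM, which is a limit and not a number.

The next change leads to compound 4 `CC(C)c1ccccc1Nc1nc(Nc2ccc(N3CCN(C)CC3)cn2)ncc1Cl`: 2-isopropylphenyl in place of 3-methoxybenzyl on a nitrogen on an aromatic ring. In words, 2-isopropylphenyl stands in place of 3-methoxybenzyl on a nitrogen on an aromatic ring.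

Within the data shown here, only one measured step bears on this, and only loosely: a 1.1-fold higher number from compound 2 to compound 3 (0.05 log units; within the scatter), where methoxy replaces hydrogen on an aromatic carbon of the same benzyl group. Among the measured compounds shown here, no measured step replaces the whole group on that nitrogen, so the direction in this assay stays open and a change beyond the scatter is not firmly expected. The expected step is a 1.3-fold lower number from compound 3 to compound 4 (0.11 log units; within the scatter). Compound 4 is estimated at 15000 nM, with an expected range of 4000 nM to 60000 nM.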

Compound 4, concentration for 50% growth inhibition: 4360 nM
Compound 4: the middle estimate sits 3.4-fold (0.54 log units) above what was measured; low and high end bracket the measured number.
By their numbers in this assay, from the lowest: compound 4; then compounds 2 and 3 (each within the scatter of the next). At a limit, above all of these: compound 1.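

In this assay, the group on this nitrogen is the only place shown where a change moves the number beyond the scatter, with a 4.5-fold lower number from compound 3 to compound 4 (0.65 log units; beyond the scatter) and, from the unsubstituted benzyl, a 4.0-fold lower number from compound 2 to compound 4 (0.60 log units; beyond the scatter) as a matching result. On the benzyl group itself, methoxy for hydrogen gave only a 1.1-fold higher number from compound 2 to compound 3 (0.05 log units; within the scatter) and stays within the scatter, so what matters here is replacing the whole group and not that substituent. The size of the substituent alone does not account for the step, since 3-methoxybenzyl and 2-isopropylphenyl carry the same count of heavy atoms and one six-membered aromatic ring each.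

Loss of the benzyl carbon link and arrival of the isopropyl remain unseparated, and a 2-methoxyphenyl or a cyclohexyl on that nitrogen would bear on each. No measurement shown gives a reason for the step.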